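The source may report more compounds than this note shows. Statements on the series, on what has been measured and on what is new or still open speak of the compounds shown alone.

Compound 1 `N#Cc1ccc(/C=N/Nc2nc(N)c3ncn([C@@H]4O[C@H](CO)[C@@H](O)[C@H]4O)c3n2)cc1`: 4.1 nM
Compound 2 `Nc1nc(N/N=C/c2ccc(N3CCCC3)cc2)nc2c1ncn2[C@@H]1O[C@H](CO)[C@@H](O)[C@H]1O`: 5.1 nM
Compound 3 `Nc1nc(N/N=C/c2ccc3ncccc3c2)nc2c1ncn2[C@@H]1O[C@H](CO)[C@@H](O)[C@H]1O`: 9.8 nM

The three measured compounds share one core and differ only in the group on the carbon with a double bond to nitrogen. In an assay on CHO-K1 cells for displacement of a labelled ligand from adenosine receptor A1 (Homo sapiens), read by scintillation counting, with a stated time of 60 min (on this read-out lower numbers stand for stronger inhibition and higher numbers for weaker inhibition), compound 1 gives 4.1 nM, compound 2 gives 5.1 nM and compound 3 gives 9.8 nM. Compound 2 stands second of the three numbers; its nearest neighbour is compound 1, a 1.2-fold higher number from compound 1 to compound 2 (0.09 log units; within the scatter), and its furthest is compound 3, a 1.9-fold higher number from compound 2 to compound 3 (0.28 log units; within the scatter), both within the scatter. Within the data shown here, only the step of a 2.4-fold higher number from compound 1 to compound 3 (0.38 log units; beyond the scatter) goes beyond the scatter, and it is modest.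

Compound 4 `CCCOc1ccc(/C=N/Nc2nc(N)c3ncn([C@@H]4O[C@H](CO)[C@@H](O)[C@H]4O)c3n2)cc1` is not yet measured. It differs from compound 2 by propoxy in place of pyrrolidin-1-yl on an aromatic carbon. The step that bears on it most directly is the exchange of groups on the same aromatic carbon, a 1.2-fold higher number from compound 1 to compound 2 (0.09 log units; within the scatter), which stayed within the scatter although cyano and pyrrolidin-1-yl are quite different groups. The two steps that exchange the whole aryl group were small as well. A step of no more than the scatter is therefore expected, with no direction favoured, estimated as a 1.2-fold higher number from compound 2 to compound 4 (0.07 log units; within the scatter). Compound 4 is expected to give 6 nM in this assay, within 2.5 nM to 15 nM.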

Compound 4, inhibition constant: > 10000 nM
Compound 4: no number, only a limit (the forecaster's own chance of this, stated with the estimate: 2%); middle value at least 1600-fold (3.22 log units) away from the limit.
By their numbers in this assay, from the lowest: compounds 1, 2 and 3 (each within the scatter of the next, the first and the last beyond it). At a limit, above all of these: compound 4.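

In this assay compound 4 carries only a limit of the assay and no number: the limit of > 10000 nM in this assay, at which 1 of the 4 values shown sits. The group on this aromatic carbon, para to a large group, is not interchangeable after all: propoxy for pyrrolidin-1-yl gives an at least 1900-fold higher number from compound 2 to compound 4 (3.29 log units; beyond the scatter), and propoxy for cyano gives an at least 2400-fold higher number from compound 1 to compound 4 (3.38 log units; beyond the scatter), whereas the exchange of cyano for pyrrolidin-1-yl gave a 1.2-fold higher number from compound 1 to compound 2 (0.09 log units; within the scatter). The exchange of the whole aryl group tells the same, with an at least 1000-fold higher number from compound 3 to compound 4 (3.00 log units; beyond the scatter), so the tolerance seen across three quite different groups in compound 1, compound 2 and compound 3 does not extend to 4-propoxyphenyl.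

Still open, on these data alone, is whether the drop belongs to the oxygen of propoxy or to its open chain: methoxy, a butyl chain or a morpholine ring on the same aromatic carbon would begin to separate the two. Also open, as far as these compounds go, is how far the true value of compound 4 lies past its limit, so each of the new steps gives a minimum size only.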